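The source may report more compounds than this note shows. Statements on the series, on what has been measured and on what is new or still open speak of the compounds shown alone.

Of the compounds shown here, three that share one core have been measured in a functional assay for inhibition, tested at 20 ug/mL; a higher number here means a stronger effect of the compound at the concentration tested, a lower number a weaker effect. Compound 1, `COc1cc(-c2cc(-c3cc(C(C)C)c(O)cc3C)[nH]c(=O)c2C#N)cc(OC)c1OC`, gives 35%. Compound 2, `COc1cccc(-c2cc(-c3cc(C(C)C)c(O)cc3C)[nH]c(=O)c2C#N)c1`, gives 22%, the lowest of the three numbers. Within the data shown here, compound 3, `COc1ccc(-c2cc(-c3cc(C(C)C)c(O)cc3C)[nH]c(=O)c2C#N)c(OC)c1`, gives 27%, so that the step of a number 5 percentage points higher from compound 2 to compound 3 (within the scatter) stays within the scatter, while compound 1 stands beyond the scatter above compound 2; for compound 1 and compound 2 only the two values themselves are known, no single step.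

Compound 4, `COc1ccc(-c2cc(-c3cc(C(C)C)c(O)cc3C)[nH]c(=O)c2C#N)cc1`, is not yet measured. It differs from compound 2 in one place: 4-methoxyphenyl in place of 3-methoxyphenyl on an aromatic carbon. Among the measured compounds shown here, the one measured step that touches the same group is the change from compound 2 to compound 3, in which a 2,4-dimethoxyphenyl replaced the 3-methoxyphenyl and the inhibition moved only within the scatter. Moving the single methoxy group on that ring is therefore expected to leave the inhibition about where compound 2 stands, with a step of a number 3 percentage points higher from compound 2 to compound 4 (within the scatter) of no size beyond the scatter. Compound 4 is thus estimated to give 25%, within a range from 10% to 40%.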

Compound 4, a percentage reported as inhibition, at one concentration (the size of the read-out at that concentration, not a potency): 24%
For compound 4 the middle estimate is 1 percentage points above the measured one, and the stated range covers the measured number.
By their numbers in this assay, from the lowest: compounds 2, 4, 3 and 1 (each within the scatter of the next, the first and the last beyond it).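

In this assay, among these compounds, moving the single methoxy group around the phenyl ring, from 3-methoxyphenyl to 4-methoxyphenyl, barely registers (a number 2 percentage points higher from compound 2 to compound 4 (within the scatter)), so the two placements cannot be told apart at this position. The earlier compounds shown here could not show this, since compound 2 and compound 3 differ in both the number and the placement of the methoxy groups, whereas compound 4 separates the two: taking one methoxy group off the 2,4-dimethoxyphenyl ring also stays small (a number 3 percentage points lower from compound 3 to compound 4 (within the scatter)). No measurement is available that would explain why these changes do so little.

As far as these compounds go, all of these rings carry only methoxy groups, so it remains open whether an amine or a carboxylic acid at this position would move the inhibition beyond the scatter. The same question stands for a longer chain, such as butoxy, in place of methoxy.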